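This account rests on a few compounds, and the source may have more. Where it says the series, first, only, none or still open, it means among the compounds named here.

Of the compounds shown here, three built on one shared core have been tested in a functional assay on HOP-92 cells (Homo sapiens) for inhibition, read by sulforhodamine B assay, with a stated time of 48 h (on this read-out lower numbers stand for stronger inhibition of growth and higher numbers for weaker inhibition of growth), a measure of how strongly a compound slows the growth of a lung cancer cell line. Compound 1 `COc1ccc(CNc2nc3cc(N)cc(N)c3nc2-c2ccccc2)cc1OC` gives 13500 nM. Compound 2 `Nc1cc(N)c2nc(-c3ccccc3)c(NCc3ccc(F)cc3)nc2c1` gives 3310 nM. Compound 3 `COc1ccc(CNc2nc3cc(N)cc(N)c3nc2-c2ccccc2)cc1` gives 12900 nM. Among these three numbers compound 2 stands lowest, and both of its steps lie beyond the scatter: the step of a 3.9-fold higher number from compound 2 to compound 3 (0.59 log units; beyond the scatter) and the step of a 4.1-fold lower number from compound 1 to compound 2 (0.61 log units; beyond the scatter), whereas the step of a 1.0-fold lower number from compound 1 to compound 3 (0.02 log units; within the scatter) stays within the scatter.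

Compound 4 `Nc1cc(N)c2nc(-c3ccccc3)c(Oc3ccc(F)cc3)nc2c1` differs from compound 2 in one place: 4-fluorophenoxy in place of (4-fluorobenzyl)amino on an aromatic carbon. Going by the values given here, every measured step changes only the substituents on the outer ring, as in a 4.1-fold lower number from compound 1 to compound 2 (0.61 log units; beyond the scatter) and a 3.9-fold higher number from compound 2 to compound 3 (0.59 log units; beyond the scatter); no measured pair changes the link between the core and that ring, so no step speaks directly to this change. The 4-fluorophenyl ring that accompanies the lowest number is kept, but the link itself is new, and the direction of its effect is not known from these data. The expectation is a modest weakening, with the step of a 2.4-fold higher number from compound 2 to compound 4 (0.38 log units; beyond the scatter), so compound 4 is estimated at 8000 nM, within a range from 2500 nM to 25000 nM.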

Compound 4, concentration for 50% growth inhibition: 12300 nM
Compound 4: the middle estimate sits 1.5-fold (0.19 log units) below what was measured; the measured number falls inside the stated range.
By their numbers in this assay, from the lowest: compound 2; then compounds 4, 3 and 1 (each within the scatter of the next).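

In this assay, going by these compounds alone, the change from (4-fluorobenzyl)amino to 4-fluorophenoxy gives a 3.7-fold higher number from compound 2 to compound 4 (0.57 log units; beyond the scatter), the first measured step that alters the link to the outer ring rather than a substituent on that ring. With the 4-fluorophenyl ring kept, this shows that the link at this aromatic carbon matters in its own right: the 4-fluorophenoxy group goes with weaker inhibition of growth than the (4-fluorobenzyl)amino group, so the fluorine alone does not secure the lower number. No measurement here explains the shift, so the reason for it stays unknown.

This single swap changes two things at once, since the link's nitrogen gives way to an oxygen and the saturated chain carbon disappears, and the step cannot show which of the two accounts for the weaker inhibition. A 4-fluorobenzyloxy group, which keeps the chain carbon with an oxygen, and a 4-fluoroanilino group, which keeps the nitrogen without that carbon, would each change only one of these features and so could pull the two apart.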